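This account rests on a few compounds, and the source may have more. Where it says the series, first, only, none or still open, it means among the compounds named here.

Measured so far in an assay on HEK293 cells for displacement of a labelled ligand from 5-hydroxytryptamine receptor 6 (Homo sapiens), read by radioligand binding, with a stated time of 60 min, tested at 100 nM; on this read-out higher numbers stand for more inhibition at the one concentration tested (going by the name of the read-out) and lower numbers for less inhibition:
- compound 1 `CN(c1ccccc1)S(=O)(=O)c1ccc2c(c1)sc(=O)n2CCN1CCCCC1`, which gives 0%
- compound 2 `CN(C)CCn1c(=O)sc2cc(S(=O)(=O)N(C)c3cccc4ccccc34)ccc21`, which gives 0%
- compound 3 `CN(c1cccc2ccccc12)S(=O)(=O)c1ccc2c(c1)sc(=O)n2CCN1CCCC1`, which gives 40%

Compound 3 holds the highest of the three numbers; compound 1 and compound 2 each lie a full step below it, beyond the scatter. Among the measured compounds shown here, the only step measured between compounds differing in one place is a number 40 percentage points higher from compound 2 to compound 3 (beyond the scatter), a change from an acyclic to a cyclic amine on the chain.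

Compound 4 `CN(c1cccc2ccccc12)S(=O)(=O)c1ccc2c(c1)sc(=O)n2CCN1CCCCC1` differs from compound 3 as follows: piperidin-1-yl in place of pyrrolidin-1-yl on a saturated chain carbon, two bonds along the chain from an aromatic nitrogen. For the measured compounds named here, no measured step concerns a pyrrolidine-to-piperidine change. Going by the values given here, compound 1 carries the piperidine ring but also a different aryl group, so its value shows only that a piperidine compound can give a low number here, not what this single change does. The step from compound 2 to compound 3 says nothing about ring size. The direction of a number 12 percentage points lower from compound 3 to compound 4 (beyond the scatter) is therefore unclear and is expected to be modest, possibly within the scatter. Compound 4 is estimated at 28%, within 0% to 55%.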

Compound 4, a percentage reported as inhibition, at one concentration (the size of the read-out at that concentration, not a potency): 14%
Estimate against measurement, compound 4: 14 percentage points above; the range from low to high includes it.
By their numbers in this assay, from the lowest: compounds 1 and 2 (each within the scatter of the next); then compound 4; then compound 3.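

In this assay, ring size at this place counts on its own: with the naphthalen-1-yl group held fixed, piperidin-1-yl in place of pyrrolidin-1-yl gives a number 26 percentage points lower from compound 3 to compound 4 (beyond the scatter) and removes much of the gain seen with the smaller ring. That gain over the open amine is only partly kept, with piperidin-1-yl in place of dimethylamino giving a number 14 percentage points higher from compound 2 to compound 4 (beyond the scatter) against a number 40 percentage points higher from compound 2 to compound 3 (beyond the scatter) for pyrrolidin-1-yl, while the group on the sulfonamide nitrogen also counts, with naphthalen-1-yl in place of phenyl giving a number 14 percentage points higher from compound 1 to compound 4 (beyond the scatter) on the same 2-(piperidin-1-yl)ethyl chain. No measurement at hand explains these steps.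

Open, on these data alone, is whether the fall continues with azepan-1-yl on the same chain, and how morpholin-4-yl compares with piperidin-1-yl. A propyl chain carrying pyrrolidin-1-yl would show whether chain length matters as much as ring size.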